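From hexyl to 3-chloropropyl on a shared core

A few compounds are considered here, and "the series" means these few. Any claim that something is new, unique, unknown or untested is made for them only; others in the source may bear on it.

In a functional assay on MiaPaCa cells (Homo sapiens) for antiproliferative activity, read by sulforhodamine B assay, with a stated time of 48 h (on this read-out lower numbers stand for stronger inhibition of growth and higher numbers for weaker inhibition of growth), compound 2 `CCCCCCc1cn(CCCN2C(=O)COc3ccccc32)nn1` gives 150 nM, the lower of the two numbers obtained so far. Compound 3 `CCCc1cn(CCCN2C(=O)COc3ccccc32)nn1` gives 2600 nM. Compound 1 `COc1ccc2cc(-c3cn(CCCN4C(=O)COc5ccccc54)nn3)ccc2c1` gives no number, only a limit of the assay, > 100000 nM.

The next compound to be tested is compound 4 `O=C1COc2ccccc2N1CCCn1cc(CCCCl)nn1`. Its difference from compound 2 is chloro in place of propyl on a saturated chain carbon, three bonds along the chain from an aromatic carbon, so that hexyl becomes 3-chloropropyl.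

For the measured compounds named here, one measured step bears on this change, a 17-fold higher number from compound 2 to compound 3 (1.24 log units; beyond the scatter). That large step, beyond the scatter, removes the same propyl at the same place, with hydrogen in its place rather than chloro. Going by the values given here, no measured step shows how chloro compares with hydrogen there. A step of similar size in the same direction is therefore expected in this assay, towards a higher number and weaker inhibition of growth, and the expected change is a 13-fold higher number from compound 2 to compound 4 (1.12 log units; beyond the scatter). For compound 4 the estimated value is 2000 nM, with an expected range from 400 nM to 10000 nM.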

Compound 4, concentration for 50% growth inhibition: 12500 nM
Compound 4: middle estimate off by 6.3-fold (0.80 log units), on the low side, outside the stated range (above it).
By their numbers in this assay, from the lowest: compound 2; then compound 3; then compound 4. At a limit, above all of these: compound 1.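

In this assay, the chain on the shared core proves more sensitive than the earlier pair suggested, with an 83-fold higher number from compound 2 to compound 4 (1.92 log units; beyond the scatter), a larger step than a 17-fold higher number from compound 2 to compound 3 (1.24 log units; beyond the scatter). Chloro at the end of the chain does not make up for any of what is lost on going from hexyl to propyl, as a 4.8-fold higher number from compound 3 to compound 4 (0.68 log units; beyond the scatter) shows; this modest step beyond the scatter points the same way as the loss of chain, towards weaker inhibition of growth. Among the compounds with a saturated chain, hexyl therefore stays the best-performing group at this place, and no measurement shown here gives a reason for the effect of the chloro.

From the compounds shown here alone, what remains open is whether chloro would cost as much on a longer chain, such as 6-chlorohexyl, and whether a chain longer than hexyl, such as octyl, would bring the number lower still. Going by these compounds, it is equally open how a hydroxyl, an amine or a carboxylic acid at the end of the propyl chain would compare with chloro at that same place.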